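This account rests on a few compounds, and the source may have more. Where it says the series, first, only, none or still open, it means among the compounds named here.

The account concerns a small set of compounds built on a shared core. Compound 1 `CN(C)CCCCN(C(=O)O)c1ccccc1Cn1nc(-c2ccc(F)cc2)c2ccccc2c1=O` and compound 2 `CN(C)CCCCOC(=O)Nc1ccc(Cn2nc(-c3cccnc3)c3ccccc3c2=O)cc1` have both been measured in an ADME assay on Huh-7 cells (Homo sapiens) for cytotoxicity, read by MTT assay, with a stated time of 48 h; a lower number here means that less compound is tolerated, a higher number that more compound is tolerated. In this assay compound 1 gives 48500 nM, and compound 2 gives 68000 nM. The two numbers lie within the usual scatter of each other, so compound 2 cannot be said to be tolerated any differently from compound 1; it stands beside it, not apart from it.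

Compound 3 `CN(C)CCCCOC(=O)Nc1ccc(Cn2nc(-c3ccccc3C#N)c3ccccc3c2=O)cc1` has not yet been measured. It differs from compound 2 by 2-cyanophenyl in place of pyridin-3-yl on an aromatic carbon. For the measured compounds named here, no measured pair shows what such a change does in this assay, so nothing in the data points in either direction. The step of a 1.4-fold lower number from compound 2 to compound 3 (0.13 log units; within the scatter) is therefore expected to be small, at most a movement no larger than the scatter, and its direction is left open. Compound 3 is expected to give 50000 nM, with a range from 20000 nM to 120000 nM.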

Compound 3, half-maximal cytotoxic concentration: 90700 nM
The estimate for compound 3 lay 1.8-fold (0.26 log units) below the measured number; measured number inside the range.
By their numbers in this assay, from the lowest: compounds 1, 2 and 3 (each within the scatter of the next).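

In this assay, for the compounds shown here, the change to 2-cyanophenyl in place of pyridin-3-yl, on the aromatic carbon next to the ring nitrogen, gives a 1.3-fold higher number from compound 2 to compound 3 (0.13 log units; within the scatter) and is the first step at this position that can be read between two measured compounds. It shows that here a six-membered aromatic ring of carbon only, carrying a nitrile, can replace a ring with one hetero atom without a difference that stands clear of the scatter. Nothing at hand gives a reason for this result.

One step at one position cannot show how far this tolerance extends. From the compounds shown here alone, whether a morpholine, a carboxylic acid or a simple methyl in this place would also stay within the scatter of compound 2 remains open, as does whether the same change would behave alike on a different side chain.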